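The source may report more compounds than this note shows. Statements on the series, on what has been measured and on what is new or still open speak of the compounds shown alone.

The measured compounds and their values in a functional assay on NCI-H1975 cells (Homo sapiens) for antiproliferative activity, read by MTT assay, with a stated time of 72 h; on this read-out higher numbers stand for weaker inhibition and lower numbers for stronger inhibition:

Compound 1 `COc1ccc(Nc2ncnc3cc(OC)c(OCCCCC(=O)Nc4ccc(S(N)(=O)=O)cc4)cc23)cc1OC`, with 9230 nM.
Compound 2 `COc1cc2ncnc(Nc3ccc(OC(F)(F)F)cc3)c2cc1OCCCCC(=O)Nc1ccc(S(N)(=O)=O)cc1`, with 8770 nM.
Compound 3 `COc1cc2ncnc(Nc3ccc(C(F)(F)F)cc3)c2cc1OCCCCC(=O)Nc1ccc(S(N)(=O)=O)cc1`, with 12000 nM.

Compound 3 gives the highest of the three numbers, but its separation from the others is small: a 1.3-fold higher number from compound 1 to compound 3 (0.11 log units; within the scatter) and a 1.4-fold higher number from compound 2 to compound 3 (0.14 log units; within the scatter), both within the scatter, as is a 1.1-fold lower number from compound 1 to compound 2 (0.02 log units; within the scatter). On these numbers the three compounds cannot be told apart.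

Compound 4 `CCc1ccc(Nc2ncnc3cc(OC)c(OCCCCC(=O)Nc4ccc(S(N)(=O)=O)cc4)cc23)cc1` differs from compound 3 by a single change: ethyl in place of trifluoromethyl on an aromatic carbon. Among the measured compounds shown here, the steps that bear on it are those that alter the same aryl group on the anilino nitrogen, and each of them stayed within the scatter. For the measured compounds named here, nothing measured so far suggests that a change at this position moves the read-out by more than the usual repeat-to-repeat variation, so the expected step of a 1.2-fold lower number from compound 3 to compound 4 (0.08 log units; within the scatter) is essentially none beyond the scatter. Compound 4 is therefore expected to give about 10000 nM, with a range from 5000 nM to 20000 nM.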

Compound 4, half-maximal inhibitory concentration: 10300 nM
The estimate for compound 4 lay 1.0-fold (0.01 log units) below the measured number, and the stated range covers the measured number.
By their numbers in this assay, from the lowest: compounds 2, 1, 4 and 3 (each within the scatter of the next).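

Among the compounds shown here, until this result, every group on the aryl ring at the anilino nitrogen carried oxygen or fluorine, and ethyl, made of carbon alone, still leaves the read-out in this assay within the scatter against each earlier compound (a 1.2-fold lower number from compound 3 to compound 4 (0.07 log units; within the scatter); a 1.2-fold higher number from compound 2 to compound 4 (0.07 log units; within the scatter); a 1.1-fold higher number from compound 1 to compound 4 (0.05 log units; within the scatter)). Removing the fluorine from this substituent therefore does not separate compound 4 from compound 3, and compound 4 cannot be told apart from compound 1 or compound 2 either. Nothing available explains this flat response.

The compounds shown leave open whether an amine or a carboxylic acid on this ring would move the read-out beyond the scatter. They also leave open whether a shorter or longer chain between the shared core and the amide would do so.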